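The source may report more compounds than this note shows. Statements on the series, on what has been measured and on what is new or still open speak of the compounds shown alone.

Compound 1 `CCN(C(=O)CC(CC(=O)NCCN1CCCCC1)c1ccc(Cl)cc1)C1Cc2ccccc2C1`: 187000 nM
Compound 2 `CCN(CC)CCNC(=O)CC(CC(=O)N(CC)C1Cc2ccccc2C1)c1ccc(Cl)cc1`: 91800 nM

For the measured compounds named here, in a toxicity assay on Vero cells (Chlorocebus sabaeus) for inhibition (a lower number here means that less compound is tolerated, a higher number that more compound is tolerated), compound 2 gives 91800 nM, the lowest of the two numbers so far, while compound 1 gives 187000 nM. The next compound, compound 3 `CCNCCNC(=O)CC(CC(=O)N(CC)C1Cc2ccccc2C1)c1ccc(Cl)cc1`, has not yet been measured. It differs from compound 2 in one place: hydrogen in place of ethyl on an amine nitrogen. In words, this is hydrogen in place of ethyl on an amine nitrogen, so diethylamino becomes ethylamino.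

Going by the values given here, only one measured step bears on this change: a 2.0-fold lower number from compound 1 to compound 2 (0.31 log units; beyond the scatter). There, diethylamino took the place of piperidin-1-yl on a saturated chain carbon, two bonds along the chain from an amide-type nitrogen. That step altered the same amine end, but it is a different change and a modest one. Among the compounds with values here, no measurement yet shows what removing a single ethyl does. A small step is therefore expected in this assay, with no firm direction and quite possibly nothing beyond the scatter. The estimate amounts to a 1.1-fold higher number from compound 2 to compound 3 (0.04 log units; within the scatter). For compound 3 the expected value is 100000 nM, with an estimated range from 45000 nM to 200000 nM.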

Compound 3, half-maximal cytotoxic concentration: 144000 nM
Beside the measured number, compound 3's estimate is 1.4-fold (0.16 log units) below it; the measured number falls inside the stated range.
By their numbers in this assay, from the lowest: compounds 2, 3 and 1 (each within the scatter of the next, the first and the last beyond it).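

In this assay, removing one ethyl from the amine nitrogen gives a 1.6-fold higher number from compound 2 to compound 3 (0.20 log units; within the scatter), so this first measured change of substitution on that nitrogen, turning diethylamino into ethylamino, stays inside the usual scatter. Ethylamino in place of piperidin-1-yl on the saturated chain carbon gives a 1.3-fold lower number from compound 1 to compound 3 (0.11 log units; within the scatter), also within the scatter, so compound 3 cannot be separated from either compound 1 or compound 2, even though a 2.0-fold lower number from compound 1 to compound 2 (0.31 log units; beyond the scatter) lies just beyond it. No supporting measurement is available to explain these differences.

Going by these compounds, it remains open whether a primary amine in place of ethylamino, or a longer chain leading to the amine, would stay within the scatter of compound 3 in this assay. Also open, on these data alone, is how this read-out responds to a change away from the amine end, since the rest of the structure is the same in all three compounds.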